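From methoxycarbonyl to cyclopentyl on compound 1

This account rests on a few compounds, and the source may have more. Where it says the series, first, only, none or still open, it means among the compounds named here.

In a functional assay on DU-145 cells (Homo sapiens) for inhibition, read by trypan blue exclusion, with a stated time of 72 h (on this read-out lower numbers stand for stronger inhibition and higher numbers for weaker inhibition), compound 1 (`COC(=O)Cn1c(=O)c(S(=O)(=O)c2ccc(F)cc2F)cc2cnc(Nc3ccc4[nH]ccc4c3)nc21`) gives 10000 nM and compound 3 (`Cn1c(=O)c(S(=O)(=O)Nc2ccc(F)cc2F)cc2cnc(Nc3ccc4[nH]ccc4c3)nc21`) gives 5000 nM so these two lie within the scatter of each other and together form the weak end of the three measured numbers. Going by the values given here, compound 2 (`Cn1c(=O)c(S(=O)(=O)c2ccc(F)cc2F)cc2cnc(Nc3cnc4[nH]ccc4c3)nc21`) gives 750 nM and is the only compound beyond the scatter of compound 1, on the side of stronger inhibition.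

Compound 4 (`O=c1c(S(=O)(=O)c2ccc(F)cc2F)cc2cnc(Nc3ccc4[nH]ccc4c3)nc2n1CC1CCCC1`) is still unmeasured. It carries cyclopentyl in place of methoxycarbonyl on a saturated chain carbon bound to an aromatic nitrogen. Among the compounds with values here, no two measured compounds differ in one place only, so no measured step speaks directly to this change.

A modest move toward lower numbers is expected in this assay although the support is thin. Compound 1 at 10000 nM already stands at the weak end, and compound 2 at 750 nM shows how low the numbers reach with other changes. The estimated step is a 3.3-fold lower number from compound 1 to compound 4 (0.52 log units; beyond the scatter) and it may prove to be no step beyond the scatter. For compound 4 the estimated value is 3000 nM with an expected range from 800 nM to 10000 nM in this read-out.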

Compound 4, half-maximal inhibitory concentration: 10000 nM
Compound 4: middle estimate off by 3.3-fold (0.52 log units), on the low side; measured number inside the range.
By their numbers in this assay, from the lowest: compound 2; then compounds 3, 1 and 4 (each within the scatter of the next).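

In this assay, going by these compounds alone, the exchange of methoxycarbonyl for cyclopentyl on a saturated chain carbon bound to an aromatic nitrogen gives no change at the digits printed from compound 1 to compound 4 (within the scatter) and is the only step that differs in one place. At this place, a group with no ring and 2 hydrogen-bond acceptors and a group with one five-membered carbon ring and 0 hydrogen-bond acceptors therefore read alike, so in this pair neither the ring nor the loss of those acceptors moves the number away from the weak end of the series. No measurement at hand accounts for this flat step, and the reading stands as an observation only.

On these data alone, whether the flat reading holds for other groups at this place stays open, for instance a carboxylic acid, a dimethylaminoethyl chain or a longer unbranched alkyl chain. As far as these compounds go, compounds 2 and 3 each differ from compound 1 and compound 4 in more than one place, so it also remains open whether this exchange would read the same on a compound that starts from a lower number.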